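Cyclopentyl, phenyl, and ethoxyphenyl on the piperidine side of an amide

This account rests on a few compounds, and the source may have more. Where it says the series, first, only, none or still open, it means among the compounds named here.

Compound 1 `COc1cc(N)c(Cl)cc1NC(=O)C1CCN(CC2CCCC2)CC1` stands only at a limit of a functional assay on the whole organism for antagonist activity, with Mus musculus as the target; on this read-out higher numbers stand for an effect only at larger amounts of compound and lower numbers for an effect already at smaller amounts: in this assay compound 1 gives > 10 mg/kg, a limit rather than a number. The change to compound 4 `CCOc1ccc(CN2CCC(C(=O)Nc3cc(Cl)c(N)cc3OC)CC2)cc1` is 4-ethoxyphenyl in place of cyclopentyl on a saturated chain carbon bound to an amine nitrogen in a ring. Going by the values given here, two measured steps bear on it. Compound 2 `COc1cc(N)c(Cl)cc1NC(=O)C1CCN(Cc2ccccc2)CC1` gives 0.5 mg/kg in this assay, and the step of an at least 20-fold lower number from compound 1 to compound 2 (1.30 log units; beyond the scatter) shows that a phenyl on that carbon moves the number far down. Compound 3 `COc1cc(N)c(Cl)cc1NC(=O)C1CCN(Cc2ccc(C)c(C)c2)CC1`, however, sits at a limit: in this assay compound 3 gives > 8 mg/kg. The step of an at least 16-fold higher number from compound 2 to compound 3 (1.20 log units; beyond the scatter) shows that methyl groups on that phenyl undo most of the gain, and the step that the two limits leave unreadable from compound 1 to compound 3. A 4-ethoxyphenyl is a phenyl carrying a group, so the expected outcome lies between compound 2 and compound 3. Compound 4 is therefore expected to give 3 mg/kg, within a range of 0.5 mg/kg to 15 mg/kg, which means an expected step of an at least 3.3-fold lower number from compound 1 to compound 4 (0.52 log units; beyond the scatter).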

Compound 4, dose for half-maximal effect: 6.3 mg/kg
The estimate for compound 4 lay 2.1-fold (0.32 log units) below the measured number; the measured number falls inside the stated range.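

Ethoxy in place of hydrogen on an aromatic carbon brings a 13-fold higher number from compound 2 to compound 4 (1.10 log units; beyond the scatter), so in this assay a phenyl carrying this one group loses most of what phenyl gained, and the loss is no longer tied to the two methyl groups of compound 3. Against cyclopentyl, 4-ethoxyphenyl gives an at least 1.5-fold lower number from compound 1 to compound 4 (0.20 log units; that floor lies within the scatter), a floor only, set by a limit of compound 1: the limit of > 10 mg/kg in this assay, at which 1 of the 4 values shown sits. Against 3,4-dimethylphenyl, it gives an at least 1.2-fold lower number from compound 3 to compound 4 (0.10 log units; that floor lies within the scatter), again a floor only, set by a limit of compound 3: the limit of > 8 mg/kg in this assay, at which 1 of the 4 values shown sits.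

From the compounds shown here alone, what a methoxy, a fluorine or an amine on that phenyl would do to the number stays open. So does the effect of a longer chain in place of the single saturated carbon bound to the ring amine nitrogen.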